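Lengthening the Ether Chain of Compound 2

The compounds below may be only part of what the source reports. "The series", "measured", "known", "first", "only" and "open" are said of these compounds alone.

Of the compounds shown here, two have so far been measured in a functional assay on ileum for antagonist activity at 5-hydroxytryptamine receptor 3A (Cavia porcellus); on this read-out lower numbers stand for tighter binding and higher numbers for weaker binding. Compound 1 `COc1nc2ccccc2nc1C(=O)Nc1ccc(O)c(CN2CCCCC2)c1` gives 316000 nM in this assay. Compound 2 `CCN1CCN(Cc2cc(NC(=O)c3nc4ccccc4nc3OC)cc(N3CCN(CC)CC3)c2O)CC1` gives 79400 nM in this assay, the lower of the two numbers, and its gap to compound 1 lies beyond the scatter. Compound 3 `CCOc1nc2ccccc2nc1C(=O)Nc1cc(CN2CCN(CC)CC2)c(O)c(N2CCN(CC)CC2)c1` has not yet been measured in this assay. It differs from compound 2 in one place: methyl in place of hydrogen on a saturated chain carbon bound to an oxygen on an aromatic ring, so that methoxy becomes ethoxy. Among the compounds with values here, no measured pair shows this change, so no step for it can be quoted. Since only a single carbon is added, the change is expected to produce a step of a 1.1-fold lower number from compound 2 to compound 3 (0.05 log units; within the scatter), which is not expected to reach beyond the scatter. Compound 3 is therefore estimated at 70000 nM, within a range from 25000 nM to 200000 nM.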

Compound 3, dissociation constant: > 1000000 nM
Compound 3: a limit, no number (the forecaster's own chance of this, stated with the estimate: 15%); at least 14-fold (1.15 log units) between middle value and limit.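

In this assay compound 3 gives > 1000000 nM, which is a limit of the assay and not a number. Turning methoxy into ethoxy, a change of one methyl on a saturated chain carbon bound to an oxygen on an aromatic ring, thus gives an at least 12-fold higher number from compound 2 to compound 3 (1.10 log units; beyond the scatter), which shows that this position responds strongly to even one added carbon, something the earlier compounds could not show. The step is bounded on one side only, and its full size cannot be read: the limit of > 1000000 nM in this assay, at which 1 of the 3 values shown sits.

From the compounds shown here alone, it remains open whether a longer chain or a branched one such as isopropoxy at this oxygen would also stay at the limit, or whether an amine in place of the ether would bring the read-out back towards that of compound 2. Also open, going by these compounds, is whether the same change on the core of compound 1 would give a step of similar size.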